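Swapping cyano for chloro near the assay limit

The source may hold more compounds than are shown below. What is called first, only, known or untested is meant among the compounds shown, and "the series" means these compounds.

Three relatives have been measured in a functional assay on PC-3 cells (Homo sapiens); on this read-out higher numbers stand for weaker inhibition of growth and lower numbers for stronger inhibition of growth. Compound 1 `O=S(=O)(/C=C/c1ccccc1)Cc1ccc(Nc2ncnc3ccccc23)cc1` reads > 100000 nM, which is a limit of the assay and not a number. Compound 2 `N#Cc1ccc(/C=C/S(=O)(=O)Cc2ccc(Nc3ncnc4ccccc34)cc2)cc1` reads > 100000 nM, which is also a limit and not a number. Among the compounds with values here, compound 3 `CC(C)(C)c1cc(/C=C/S(=O)(=O)Cc2ccc(Nc3ncnc4ccccc34)cc2)cc(C(C)(C)C)c1O` gives 7000 nM, the only true number so far. Compound 2 therefore stands with compound 1 at the limit of > 100000 nM in this assay, at which 2 of the 3 values shown sit.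

The next compound, compound 4 `O=S(=O)(/C=C/c1ccc(Cl)cc1)Cc1ccc(Nc2ncnc3ccccc23)cc1`, differs from compound 2 in one place: chloro in place of cyano on an aromatic carbon, para to a large group (chloro in place of cyano on an aromatic carbon).

Within the data shown here, only one measured step bears on this change: a step that the two limits leave unreadable from compound 1 to compound 2. Its size cannot be read, so it offers no measured size to carry over. Compound 1 and compound 2 both sit at the limit of > 100000 nM in this assay, at which 2 of the 3 values shown sit, which gives no sign that a small group at this place moves the read-out in this assay. No clear shift in either direction is therefore expected. The expected change is a number no higher from compound 2 to compound 4 (the limit leaves the size open), and it is only a rough estimate. Compound 4 is estimated at 100000 nM, with an expected range from 30000 nM to 200000 nM, and it will quite likely be reported only as a limit.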

Compound 4, concentration for 50% growth inhibition: 43000 nM
Beside the measured number, compound 4's estimate is 2.3-fold (0.37 log units) above it; measured number inside the range.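

The earlier pair could show nothing about this position, and the step between compound 1 and compound 2 cannot be read, because both compounds rest on the same ceiling: the limit of > 100000 nM in this assay, at which 2 of the 4 values shown sit. In this assay, chloro in place of cyano on the aromatic carbon gives an at least 2.3-fold lower number from compound 2 to compound 4 (0.36 log units; beyond the scatter) and chloro in place of hydrogen gives an at least 2.3-fold lower number from compound 1 to compound 4 (0.36 log units; beyond the scatter) with both steps beyond the usual scatter. Within the data shown here, this is the first sign that the group on this aromatic carbon can move the read-out at all, and each size is only a minimum, since compound 4 is the only one of the three with a true number.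

Chloro is a single example, so it stays open whether a methoxy group, an amine or a carboxylic acid on this carbon would also bring the read-out off the ceiling, and by how much. Compound 3 gives 7000 nM but differs from compound 4 in more than one place, so the two cannot be compared as a single change.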